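Swapping the amide aryl group: one growth-inhibition value

This account rests on a few compounds, and the source may have more. Where it says the series, first, only, none or still open, it means among the compounds named here.

Compounds measured so far in an ADME assay on RAW264.7 cells (Mus musculus) for inhibition, read by MTT assay, with a stated time of 48 h; on this read-out higher numbers stand for weaker inhibition of growth and lower numbers for stronger inhibition of growth
- compound 1 `O=C(Nc1ccc(CO)cc1)c1c(-c2ccccc2)c2cc(Cl)ccc2[nH]c1=O` gives "not determined" (no result reported)
- compound 2 `O=C(Nc1ccc(Cl)cc1)c1c(-c2ccccc2)c2cc(Cl)ccc2n(Cc2cccc(F)c2)c1=O` gives 86.8 ug/mL

Going by the values given here, compound 2 holds the only number so far, 86.8 ug/mL, and compound 1 offers no result to set beside it. There is therefore no ranking yet, and compound 2 simply serves as the single reference point.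

Compound 3 `Cc1cc(C)c(NC(=O)c2c(-c3ccccc3)c3cc(Cl)ccc3n(Cc3cccc(F)c3)c2=O)c(C)c1` keeps everything else in compound 2 and changes one group, with 2,4,6-trimethylphenyl in place of 4-chlorophenyl on an amide-type nitrogen.

Among the compounds with values here, no pair of measured compounds shows how far this assay moves when this part of the structure changes. The data therefore offer no ground for a large shift or for a firm direction, and the expectation is a change no greater than the usual scatter of repeated measurements. The expected step is a 1.1-fold lower number from compound 2 to compound 3 (0.04 log units; within the scatter). The range must stay wide, since it rests on compound 2 at 86.8 ug/mL alone. For compound 3 the estimated value is 80 ug/mL, with an expected range from 35 ug/mL to 180 ug/mL.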

Compound 3, concentration for 50% growth inhibition: 93.5 ug/mL
Estimate against measurement, compound 3: 1.2-fold (0.07 log units) below, and the stated range covers the measured number.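

In this assay, going by these compounds alone, placing 2,4,6-trimethylphenyl instead of 4-chlorophenyl on the amide-type nitrogen gives a 1.1-fold higher number from compound 2 to compound 3 (0.03 log units; within the scatter), the first measured comparison at this position. The two compounds therefore cannot be told apart in this growth-inhibition read-out, even though the groups differ in their atoms: the group that leaves has 7 heavy atoms including a chlorine, and the group that enters has 9, all carbon. No supporting measurement is available to explain this result.

This is still a single pair, and both groups are six-membered aromatic rings of carbon only, with no hydrogen-bond donors or acceptors, so it cannot show whether an amine or a carboxylic acid on that ring, or a longer alkyl chain in its place, would give a similar value. From the compounds shown here alone, it also remains open whether the same swap would give a similar result if other parts of the shared core were different.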